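Swapping Pyridin-2-yl for Hydroxymethyl in a Myosin-2 Inhibitor

The source may report more compounds than this note shows. Statements on the series, on what has been measured and on what is new or still open speak of the compounds shown alone.

Measured so far in an assay on isolated protein for inhibition of myosin-2 (Bos taurus), read by spectrophotometry, with a stated time of 24 min; a lower number here means a stronger inhibitor, a higher number a weaker inhibitor:
compound 1, `C/C(=N\Cc1ccccn1)c1c(O)c2ccccc2oc1=O`, gives 22000 nM.
compound 2, `C/C(=N\OCc1ccccc1)c1c(O)c2ccccc2oc1=O`, reaches only the limit of the assay, >= 100000 nM.
compound 3, `C/C(=N\CC(C)C)c1c(O)c2ccccc2[nH]c1=O`, also reaches only the limit of the assay, >= 100000 nM.

Within the data shown here, compound 1 therefore stands as the sole compound with an actual number in this assay; the other two sit at the limit of >= 100000 nM in this assay, at which 2 of the 3 values shown sit, which is a limit and not a measurement. Among the measured compounds shown here, no two of the measured compounds differ in a single place, so there is no measured step to serve as a yardstick.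

The next compound, compound 4, is `C/C(=N\CCO)c1c(O)c2ccccc2oc1=O`. Compared with compound 1 the change is hydroxymethyl in place of pyridin-2-yl on a saturated chain carbon bound to a double-bonded nitrogen. A ring with one hetero atom gives way to a short chain carrying a hydroxyl group, on the carbon bound to the double-bonded nitrogen.

The step from compound 1 to compound 4 is expected to be a 2.7-fold higher number from compound 1 to compound 4 (0.44 log units; beyond the scatter), a loss of potency beyond the usual scatter. Compounds 2 and 3, which also vary in this part of the molecule, both rest at the limit of >= 100000 nM in this assay, at which 2 of the 3 values shown sit, so the expectation for compound 4 leans weak and may itself end as a limit.

For compound 4 in this assay the estimate is 60000 nM, expected between 20000 nM and 150000 nM.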

Compound 4, half-maximal inhibitory concentration: 92000 nM
Compound 4: middle estimate off by 1.5-fold (0.19 log units), on the low side; the range from low to high includes it.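

In this assay this position now has its first readable step: hydroxymethyl in place of pyridin-2-yl gives a 4.2-fold higher number from compound 1 to compound 4 (0.62 log units; beyond the scatter), so on this shared core the ring of compound 1 cannot be traded for the short hydroxyl-bearing chain without a loss of potency. The change removes a ring and brings in a hydrogen-bond donor at the same time, so this single step cannot say which of the two accounts for the loss. Compound 2 and compound 3 still give no number here, only a limit of the assay: the limit of >= 100000 nM in this assay, at which 2 of the 4 values shown sit.

Open, from the compounds shown here alone, is whether the ring itself or its nitrogen matters, a question that a plain phenyl or a pyridin-3-yl on the same saturated chain carbon would address. Equally open, going by these compounds, is the part played by the hydroxyl, which a methyl in place of the hydroxymethyl, or an amine in place of the hydroxyl, would help to separate from the effect of simply losing the ring.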